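Swapping methyl for bromo on a five-ring core

The source may report more compounds than this note shows. Statements on the series, on what has been measured and on what is new or still open speak of the compounds shown alone.

Three compounds have been measured in a functional assay on T47D cells (Homo sapiens) for inhibition, read by sulforhodamine B assay, with a stated time of 48 h; a higher number here means a weaker inhibitor of growth, a lower number a stronger inhibitor of growth:

- compound 1, `COC(=O)[C@@]1(C)CCC=C2[C@@H]1CC[C@@H](C)[C@]2(C)Cc1c(C)[nH]c2c(C)cccc12`, gives 19000 nM
- compound 2, `COC(=O)[C@@]1(C)CCC=C2[C@@H]1CC[C@@H](C)[C@]2(C)Cc1c(C)[nH]c2c(Br)cccc12`, gives 31000 nM
- compound 3, `COC(=O)[C@@]1(C)CC[C@@H]2C3=C1CC[C@@H](C)[C@]3(C)Cc1c2[nH]c2c(C)cccc12`, gives 23000 nM

Compound 1 and compound 2 share one core and differ by a single change: bromo in place of methyl on an aromatic carbon. This change made a step of a 1.6-fold higher number from compound 1 to compound 2 (0.21 log units; within the scatter), so the two compounds are not separated beyond the usual scatter of repeated measurements.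

Compound 3 has a different core, and the difference between the two cores is not broken down here. Compound 4, `COC(=O)[C@@]1(C)CC[C@@H]2C3=C1CC[C@@H](C)[C@]3(C)Cc1c2[nH]c2c(Br)cccc12`, has not yet been measured. It is derived from compound 3 by bromo in place of methyl on an aromatic carbon. Going by the values given here, this is the same kind of change as the one from compound 1 to compound 2, but not the same: in compound 2 the changed carbon belongs to a fused or bridged system of two rings, while in compound 4 it belongs to a fused or bridged system of five rings.

Given the small step from compound 1 to compound 2, the expectation is that compound 4 will move by about a 1.4-fold higher number from compound 3 to compound 4 (0.14 log units; within the scatter) from compound 3, again staying within the scatter. The estimate for compound 4 in this assay is therefore 32000 nM, with a likely range from 15000 nM to 65000 nM. That expectation rests on a single earlier pair, so the actual measurement is awaited.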

Compound 4, concentration for 50% growth inhibition: 31000 nM
Beside the measured number, compound 4's estimate is 1.0-fold (0.01 log units) above it, and the stated range covers the measured number.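

In this assay, putting bromo in place of methyl on the aromatic carbon of the second core gives a 1.3-fold higher number from compound 3 to compound 4 (0.13 log units; within the scatter), so on this core, too, the swap does not separate the two compounds beyond the usual scatter of repeated measurements. Set beside the earlier pair, the change behaves the same way on both cores, with no measurable difference between the two steps: the same change on two cores in this assay, a 1.6-fold higher number (0.21 log units; within the scatter) from compound 1 to compound 2 and a 1.3-fold higher number (0.13 log units; within the scatter) from compound 3 to compound 4, 1.2-fold (0.08 log units) apart, within the scatter of two such steps. This shows that, for these two pairs in this one assay, methyl and bromo on this carbon cannot be told apart and that the core does not visibly alter the outcome, but it does not show that the two groups are interchangeable in general or that the result would hold on a third core, and two steps this small cannot reveal whether a slight real effect lies hidden in the scatter.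

The compounds shown carry only methyl or bromo at this carbon, so it remains open whether a group of a different kind there, such as an amine, a carboxylic acid or a longer chain, would move the number beyond the scatter. Going by these compounds, it also remains open whether any change elsewhere, such as a carboxylic acid in place of the methyl ester, would give a stronger inhibitor of growth on either core.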